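Swapping the aryl group on the sulfonamide nitrogen

This account rests on a few compounds, and the source may have more. Where it says the series, first, only, none or still open, it means among the compounds named here.

Measured compounds so far:
compound 1, `O=C1NCCN1c1ccc(S(=O)(=O)Nc2ccc(OC(F)F)cc2)cc1`, 410 nM in a functional assay on M21 cells (Homo sapiens) for antiproliferative activity, read by sulforhodamine B assay, with a stated time of 48 h; on this read-out lower numbers stand for stronger inhibition and higher numbers for weaker inhibition
compound 2, `O=C1NCCN1c1ccc(S(=O)(=O)Nc2ccc(F)c(F)c2)cc1`, 220 nM
compound 3, `O=C1NCCN1c1ccc(S(=O)(=O)Nc2cccc(Oc3ccccc3)c2)cc1`, 83 nM

All three share the same core and differ only in the aromatic group attached to the sulfonamide nitrogen. Compound 2 sits second highest of the three numbers. Its nearest neighbour is compound 1, whose value lies within the usual scatter of compound 2, so no order can be read between those two. Compound 3 gives a clearly lower number than compound 2, a gap beyond the scatter, so compound 3 inhibits growth more strongly.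

The next compound, compound 4, `Cc1cc(C)cc(NS(=O)(=O)c2ccc(N3CCNC3=O)cc2)c1`, follows from compound 2 by one change:
3,5-dimethylphenyl in place of 3,4-difluorophenyl on a sulfonamide nitrogen

Going by the values given here, no pair among the measured compounds shows this kind of exchange, so no measured step guides the expectation. The three measured values are all fairly close, and a 3,5-dimethylphenyl on the sulfonamide nitrogen is a change of similar scale to those seen. A step from compound 2 to compound 4 of a 1.1-fold higher number from compound 2 to compound 4 (0.06 log units; within the scatter) is expected in this assay, that is, no change beyond the scatter. Compound 4 is therefore estimated at 250 nM, with a range from 80 nM to 800 nM.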

Compound 4, half-maximal inhibitory concentration: 63 nM
Beside the measured number, compound 4's estimate is 4.0-fold (0.60 log units) above it; measured number below the stated range.
By their numbers in this assay, from the lowest: compounds 4 and 3 (each within the scatter of the next); then compounds 2 and 1 (each within the scatter of the next).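

In this assay, going by these compounds alone, the exchange on the sulfonamide nitrogen gives a 3.5-fold lower number from compound 2 to compound 4 (0.54 log units; beyond the scatter), the first step between two measured compounds that differ only in this group. It shows that this position can respond to a single swap beyond the scatter, even though 3,4-difluorophenyl and 3,5-dimethylphenyl hold the same number of heavy atoms, each have one aromatic ring of carbon and carry no hydrogen-bond donors or acceptors. Compound 4 at 63 nM and compound 3 at 83 nM lie within the scatter of each other, so no order can be read between them, and no information here explains why the exchange lowers the number.

As far as these compounds go, whether the step belongs to the methyl groups themselves or to where they sit on the ring stays open, and a 3,5-difluorophenyl group on the same nitrogen would help to separate the two. Also open, from the compounds shown here alone, is how this assay would respond to an aryl group carrying an amine or a carboxylic acid at this position.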